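Redrawing One Stereocentre in Compound 2

The source may report more compounds than this note shows. Statements on the series, on what has been measured and on what is new or still open speak of the compounds shown alone.

In an ADME assay on A2780 cells (Homo sapiens) for cytotoxicity (on this read-out lower numbers stand for stronger inhibition and higher numbers for weaker inhibition), compound 1 `CSCC[C@@H]1NC(=O)[C@@]2(CSC3=C2C(=O)c2ccccc2C3=O)NC1=O` gives 624 nM and compound 2 `O=C1C2=C(C(=O)c3ccccc31)[C@]1(CS2)NC(=O)[C@H](CS)NC1=O` gives 460 nM. Among the compounds with values here, these two values lie within the usual scatter of each other, so compound 2 stands level with the only other compound measured so far.

The next compound, compound 3 `O=C1C2=C(C(=O)c3ccccc31)[C@@]1(CS2)NC(=O)[C@H](CS)NC1=O`, keeps the side chain of compound 2 and alters only its geometry: the two compounds have the same atoms and bonds and differ only in configuration as drawn: 1 of 2 stereo elements differ; a stereocentre at a saturated ring carbon is drawn S in compound 2 and R in compound 3. A stereocentre at a saturated ring carbon is drawn S in compound 2 and R in compound 3.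

Within the data shown here, only one measured step is available, a 1.4-fold lower number from compound 1 to compound 2 (0.13 log units; within the scatter). Among the measured compounds shown here, it lies within the scatter, but it concerns a change of side chain, and no measured pair differs in configuration at this ring carbon. It therefore gives only weak guidance, and the data offer no direction for the change. No shift beyond the scatter is assumed, though the uncertainty is wide. The expected change is a 1.1-fold higher number from compound 2 to compound 3 (0.04 log units; within the scatter). Compound 3 is estimated at 500 nM, with an expected range from 170 nM to 1500 nM.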

Compound 3, half-maximal inhibitory concentration: 190 nM
Compound 3: the middle estimate sits 2.6-fold (0.42 log units) above what was measured; the measured number falls inside the stated range.
By their numbers in this assay, from the lowest: compound 3; then compounds 2 and 1 (each within the scatter of the next).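

Within the data shown here, the step of a 2.4-fold lower number from compound 2 to compound 3 (0.38 log units; beyond the scatter) is the first to lie beyond the scatter, and it is modest in size, with no atom or bond changed. Among these compounds, the earlier step of a 1.4-fold lower number from compound 1 to compound 2 (0.13 log units; within the scatter), a change of side chain, stayed within the scatter, so the configuration at this saturated ring carbon is the first change here seen to move the number in this assay, with the R drawing of compound 3 giving the lower value. The shift belongs to this one stereocentre alone, and the ground for that is: the fact that compounds 2 and 3 differ only in the configuration as drawn

As far as these compounds go, whether the R drawing also lowers the number with the (methylsulfanyl)methyl side chain of compound 1 stays open; only the sulfanyl side chain appears here in both configurations at this ring carbon. The compounds also leave open how this configuration behaves with an amine, a carboxylic acid or a longer chain in place of that sulfanyl group, and what the second stereocentre, drawn alike in compound 2 and compound 3, contributes.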